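The compounds below may be only part of what the source reports. "The series", "measured", "known", "first", "only" and "open" are said of these compounds alone.

Measured in a physicochemical assay for solubility, using the shake flask method, in simulated intestinal fluid, measured as kinetic solubility, with a stated time of 20 h, at pH 6.5 (on this read-out higher numbers stand for higher solubility and lower numbers for lower solubility), so far:
- compound 1 `FC(F)(F)c1ccc(Nc2cc3[nH]c(-c4cccc(C(F)(F)F)c4)nc3cn2)nc1` gives >= 50000 nM as a limit
- compound 2 `Fc1ccc(-c2nc3cnc(Nc4cc(C(F)(F)F)ccn4)cc3[nH]2)cc1F` gives >= 50000 nM as a limit
- compound 3 `FC1(F)CCC(c2nc3cnc(Nc4ccc(C(F)(F)F)cn4)cc3[nH]2)C1` gives 163000 nM as a number

Among the compounds with values here, compound 3 holds the only number in this set, so no ranking of the three can be read. Compound 1 and compound 2 both rest on the limit of >= 50000 nM in this assay, at which 2 of the 3 values shown sit, and give no number. Within the data shown here, the only step between measured compounds is a step that the limit leaves unreadable from compound 1 to compound 3 and it offers no size to carry forward.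

Compound 4 `CC1(c2nc3cnc(Nc4ccc(C(F)(F)F)cn4)cc3[nH]2)CC1` has not yet been measured. It carries 1-methylcyclopropyl in place of 3,3-difluorocyclopentyl on an aromatic carbon, between two ring nitrogen atoms, with 1-methylcyclopropyl in place of 3,3-difluorocyclopentyl on an aromatic carbon as the counted difference.

Among the measured compounds shown here, no measured step covers this change. The expectation therefore rests on compound 3 at 163000 nM as the sole anchor, and no step beyond the scatter is expected in this assay in either direction. The expected change is a 1.3-fold lower number from compound 3 to compound 4 (0.10 log units; within the scatter) and it has little support from the data. Compound 4 is estimated at 130000 nM with an expected range from 45000 nM to 350000 nM and a real chance of only a limit.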

Compound 4, solubility: 179000 nM
Estimate against measurement, compound 4: 1.4-fold (0.14 log units) below; the measured number falls inside the stated range.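

In this assay, the aromatic carbon between two ring nitrogen atoms now has its first readable step, with 1-methylcyclopropyl in place of 3,3-difluorocyclopentyl giving a 1.1-fold higher number from compound 3 to compound 4 (0.04 log units; within the scatter). The exchange goes from 7 heavy atoms to 4, removes both fluorine atoms and replaces a five-membered non-aromatic ring of carbon only with a three-membered one, yet the two values remain within the scatter of each other. The steps from compound 1 to compound 3 and to compound 4 cannot be read, as compound 1 gives only a limit: the limit of >= 50000 nM in this assay, at which 2 of the 4 values shown sit.

Going by these compounds, both groups compared at this place are carbon rings with no hydrogen-bond donors or acceptors and no net charge, so the effect of an amine or a carboxylic acid there remains open. On these data alone, with no number for compound 1, the comparison of 3-(trifluoromethyl)phenyl with 3,3-difluorocyclopentyl or 1-methylcyclopropyl at this place also remains open.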